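An expected value for compound 4

The compounds below may be only part of what the source reports. "The series", "measured", "known", "first", "only" and "open" are said of these compounds alone.

Measured compounds:
compound 1 `COc1ccc(/C=C/C(=O)c2ccc(OC)c3c2OC(C)(C)C=C3)c(F)c1` 7560 nM
compound 2 `COc1ccc(C(=O)/C=C/c2cccc(Cl)c2)c2c1C=CC(C)(C)O2` > 10000 nM
compound 3 `COc1ccc(C(=O)/C=C/c2ccc(Cl)c(Cl)c2)c2c1C=CC(C)(C)O2` > 10000 nM

All three were tested in a functional assay on HepG2 cells (Homo sapiens) for antiproliferative activity, read by MTT assay, with a stated time of 24 h; on this read-out higher numbers stand for weaker inhibition and lower numbers for stronger inhibition. Compound 1 gives 7560 nM. For compound 2 the value > 10000 nM is a limit of the assay and not a number. For compound 3 likewise the value > 10000 nM is a limit, so compound 3 stands at the edge of what the assay reports, at the limit of > 10000 nM in this assay, at which 2 of the 3 values shown sit.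

The step to compound 4 `COc1ccccc1/C=C/C(=O)c1ccc(OC)c2c1OC(C)(C)C=C2` is 2-methoxyphenyl in place of 3,4-dichlorophenyl on a double-bonded chain carbon bound to a double-bonded chain carbon. Going by the values given here, two measured steps bear on it. From the 2-fluoro-4-methoxyphenyl compound, an at least 1.3-fold higher number from compound 1 to compound 3 (0.12 log units; that floor lies within the scatter) and an at least 1.3-fold higher number from compound 1 to compound 2 (0.12 log units; that floor lies within the scatter) are both floors that lie within the scatter, so the exchange of the aryl group has not yet produced a readable shift. a step that the two limits leave unreadable from compound 2 to compound 3 gives no further guidance. Compound 4 returns a methoxyphenyl group, as compound 1 carries one, but without the fluoro substituent, so it is expected to sit near compound 1 and the limit, with no step beyond the scatter. Compound 4 is therefore expected at 9000 nM, with a range from 4000 nM to 20000 nM. The expected step is an at least 1.1-fold lower number from compound 3 to compound 4 (0.04 log units; that floor lies within the scatter).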

Compound 4, half-maximal inhibitory concentration: > 10000 nM
Compound 4 was reported as a limit; the forecaster's own chance of this, stated with the estimate: 45%; middle value at least 1.1-fold (0.04 log units) away from the limit.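

With compound 4, the 2-methoxyphenyl group joins the 3-chlorophenyl and 3,4-dichlorophenyl groups on a double-bonded chain carbon bound to a double-bonded chain carbon, and in this assay none of the three gives a number. A methoxyphenyl group alone therefore does not bring a value within the reported range, and a compound without chlorine ends at the same limit as the two chlorinated compounds: the limit of > 10000 nM in this assay, at which 3 of the 4 values shown sit. Going by these compounds alone, the only step that can be read is an at least 1.3-fold higher number from compound 1 to compound 4 (0.12 log units; that floor lies within the scatter), so removing the fluoro group and moving the methoxy group, as the change from 2-fluoro-4-methoxyphenyl to 2-methoxyphenyl does, shows no shift beyond the scatter; the steps joining compound 2, compound 3 and compound 4 cannot be read.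

The compounds shown leave open how far apart compound 2, compound 3 and compound 4 really lie, since their limits hide any order among them. They also leave open whether a different group at this place, such as a dimethylaminophenyl or a hydroxyphenyl group, would give a value clearly stronger than that of compound 1.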